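The source may report more compounds than this note shows. Statements on the series, on what has been measured and on what is new or still open speak of the compounds shown alone.

In an ADME assay on microsomes from liver (Homo sapiens) for metabolic stability, read by mass spectrometry, using NADPH, tested at 1.5 uM (on this read-out lower numbers stand for a shorter-lived compound and higher numbers for a longer-lived compound), compound 1 (`O=C(Nc1ccc2sc(-c3ccccc3)nc2c1)N1CCCC1`) gives 0.5 h as its half-life. Compound 2 (`O=C(Nc1ccc2oc(-c3ccccc3)nc2c1)N1CCCCC1`) gives > 1 h as a limit of the assay and not as a number. Compound 2 therefore stands at the limit of > 1 h in this assay, at which 1 of the 2 values shown sits, and offers no exact starting point. Compound 3 (`O=C(Nc1ccc2oc(-c3ccccc3)nc2c1)c1ccccc1`) carries phenyl in place of piperidin-1-yl on a carbonyl carbon and otherwise matches compound 2. Among the compounds with values here, no measured pair isolates this change, so the expectation is loose: a modest shortening, or nothing beyond the usual scatter. Within the data shown here, it leans on compound 1 with 0.5 h as the only exact number available. The expected change is an at least 1.2-fold lower number from compound 2 to compound 3 (0.09 log units; that floor lies within the scatter) in this assay on this reasoning. The estimate for compound 3 is 0.8 h with an expected range of 0.35 h to 1.6 h in this read-out.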

Compound 3, half-life: 1 h
The estimate for compound 3 lay 1.3-fold (0.10 log units) below the measured number; the range from low to high includes it.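

Replacing piperidin-1-yl with phenyl on a carbonyl carbon gives, in this assay, a number no higher from compound 2 to compound 3 (the limit leaves the size open). The size of this step cannot be read because compound 2 stands at a limit of the assay and not at a number: the limit of > 1 h in this assay, at which 1 of the 3 values shown sits. Compound 3, at 1 h, supplies the only exact number among the compounds shown that carries the core of compound 2, so the benzoyl form gives later changes on this core a firm point of comparison.

On these data alone, whether the change from (piperidin-1-yl)carbonyl to benzoyl shifts the half-life beyond the usual scatter remains open. Also open, as far as these compounds go, is how a morpholine ring or a dimethylamino group on the same carbonyl carbon would read in this assay.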